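The compounds below may be only part of what the source reports. "The series", "measured", "known", "first", "only" and "open" are said of these compounds alone.

In a functional assay on CEM-SS cells (Homo sapiens) for cytotoxicity (a higher number here means a weaker inhibitor, a lower number a stronger inhibitor), compound 3 `Cc1cccc(Cn2c(Br)nc3cc(Cl)c(Cl)cc32)c1` gives only a limit, > 100000 nM. Compound 2 `Clc1cc2nc(Br)n(Cc3ccccc3)c2cc1Cl` also gives only a limit, > 100000 nM. Together these two compounds account for (the limit of > 100000 nM in this assay, at which 2 of the 3 values shown sit). Among the measured compounds shown here, the one measured step that bears on what follows is a step that the two limits leave unreadable from compound 2 to compound 3, and it involved methyl in place of hydrogen on an aromatic carbon. That step offers no size to carry forward. For the measured compounds named here, compound 1 `Nc1nc2cc(Cl)c(Cl)cc2n1Cc1cccc(C(F)(F)F)c1`, which also carries a trifluoromethyl group, is the only compound with a true number, 34000 nM. Compound 4 `FC(F)(F)c1cccc(Cn2c(Br)nc3cc(Cl)c(Cl)cc32)c1` differs from compound 3 by one change, trifluoromethyl in place of methyl on an aromatic carbon. With so little to go on, a modest shift toward a stronger reading is expected, resting only on compound 1 at 34000 nM. A further result at the limit would be no surprise for compound 4. The expected change is an at least 1.4-fold lower number from compound 3 to compound 4 (0.15 log units; that floor lies within the scatter). For compound 4 the estimated value is 70000 nM, with an expected range from 25000 nM to 100000 nM.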

Compound 4, half-maximal inhibitory concentration: > 100000 nM
Compound 4 was reported as a limit; the forecaster's own chance of this, stated with the estimate: 55%; at least 1.4-fold (0.15 log units) between middle value and limit.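

Trifluoromethyl in place of methyl on this aromatic carbon does not bring the bromo series into measurable range: in this assay compound 4 gives > 100000 nM, which is a limit and not a true number. The steps to compound 4 from compound 2 and from compound 3 cannot be read, since all three compounds sit at the same limit: the limit of > 100000 nM in this assay, at which 3 of the 4 values shown sit. Among the compounds shown here, with trifluoromethyl now present in both compounds, the one readable comparison isolates the other site, where bromo in place of amino gives an at least 2.9-fold higher number from compound 1 to compound 4 (0.46 log units; beyond the scatter).

From the compounds shown here alone, whether a nitrile or a methoxy group on this aromatic carbon would give a true number remains open. Compound 1 is the only amino compound shown, so it also remains open how an amino compound with methyl or hydrogen in place of trifluoromethyl would read.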